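Where compound 3 stands, and a change to test

This account rests on a few compounds, and the source may have more. Where it says the series, first, only, none or still open, it means among the compounds named here.

Of the compounds shown here, three that share one core have been tested in a functional assay on the whole organism for inhibition, with Mythimna separata as the target, with a stated time of 5 days; a lower number here means that less compound is needed, a higher number that more compound is needed for the effect. Compound 1 `CC(C)(C)n1ncc(OCc2nnc(-c3ccccc3Cl)o2)c(Cl)c1=O` gives 61200 nM. Compound 3 `CC(C)(C)n1ncc(OCc2nnc(-c3ccccc3F)o2)c(Cl)c1=O` gives 16800 nM, the lowest of the two numbers reported, and the step between them is a 3.6-fold lower number from compound 1 to compound 3 (0.56 log units; beyond the scatter). For compound 2 `Cc1cc(C)cc(-c2nnc(COc3cnn(C(C)(C)C)c(=O)c3Cl)o2)c1` the assay reports only a limit, > 299000 nM. Against that background, the limit of > 299000 nM in this assay, at which 1 of the 3 values shown sits, marks where the measurable range ends.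

The unmeasured compound 4 `Cc1cccc(-c2nnc(COc3cnn(C(C)(C)C)c(=O)c3Cl)o2)c1` differs from compound 3 in one place: 3-methylphenyl in place of 2-fluorophenyl on an aromatic carbon. Two measured steps speak to this change. Replacing the 2-chlorophenyl by a phenyl carrying two methyl groups gave an at least 4.8-fold higher number from compound 1 to compound 2 (0.68 log units; beyond the scatter), and moving from that dimethylphenyl to the 2-fluorophenyl gave an at least 17-fold lower number from compound 2 to compound 3 (1.25 log units; beyond the scatter). Compound 4 carries a single methyl and no fluorine, so the step from compound 3 is expected to move toward higher numbers, in the direction seen for compound 2, though a single methyl may not reach the limit. The expected step is therefore an 8.9-fold higher number from compound 3 to compound 4 (0.95 log units; beyond the scatter), beyond the scatter. Compound 4 is expected to give about 150000 nM, within a range from 40000 nM to 300000 nM.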

Compound 4, half-maximal effective concentration: 116000 nM
Compound 4: middle estimate off by 1.3-fold (0.11 log units), on the high side; low and high end bracket the measured number.
By their numbers in this assay, from the lowest: compound 3; then compounds 1 and 4 (each within the scatter of the next). At a limit, above all of these: compound 2.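

In this assay, a single methyl is enough for a clear change: 3-methylphenyl in place of 2-fluorophenyl gives a 6.9-fold higher number from compound 3 to compound 4 (0.84 log units; beyond the scatter), so the much higher reading of compound 2 does not require a second methyl group on the phenyl ring. Going from two methyl groups to one gives an at least 2.5-fold lower number from compound 2 to compound 4 (0.41 log units; beyond the scatter), which brings the series back into the measurable range, whereas compound 2 has a limit of the assay and not a number: the limit of > 299000 nM in this assay, at which 1 of the 4 values shown sits. The 2-chlorophenyl and 3-methylphenyl groups cannot be told apart here, with a 1.9-fold higher number from compound 1 to compound 4 (0.28 log units; within the scatter), so compound 3, with its 2-fluorophenyl, now stands clearly apart from all three other compounds as having the lowest number.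

The compounds shown do not separate the kind of group on the phenyl ring from its place on that ring. As far as these compounds go, what a plain phenyl, or a phenyl carrying a methoxy group or an amine, would give in this assay also stays open.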